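This account rests on a few compounds, and the source may have more. Where it says the series, first, only, none or still open, it means among the compounds named here.

Working notes on the series, read in a functional assay on A549 cells (Homo sapiens), read by MTT assay, with a stated time of 72 h; a lower number here means a stronger inhibitor, a higher number a weaker inhibitor:

- compound 1 `CSc1ncnc2c1c(-c1ccoc1)cn2[C@@H]1O[C@H](CO)[C@@H](O)[C@H]1O`: 280 nM
- compound 2 `CSc1ncnc2c1c(-c1ccccc1)cn2[C@@H]1O[C@H](CO)[C@@H](O)[C@H]1O`: > 20000 nM (a limit of the assay)
- compound 3 `CNc1ncnc2c1c(-c1ccoc1)cn2[C@@H]1O[C@H](CO)[C@@H](O)[C@H]1O`: > 20000 nM (a limit of the assay)

Compound 3 stands at the limit of > 20000 nM in this assay, at which 2 of the 3 values shown sit, so it offers a limit and no number to start from. The next compound to be read is compound 4 `CNc1ncnc2c1c(-c1ccccc1)cn2[C@@H]1O[C@H](CO)[C@@H](O)[C@H]1O`, with phenyl in place of furan-3-yl on an aromatic carbon.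

Among the measured compounds shown here, two measured steps bear on this change. The same exchange, made on compound 1, gave an at least 71-fold higher number from compound 1 to compound 2 (1.85 log units; beyond the scatter), a large step beyond the scatter. The exchange of methylsulfanyl for methylamino gave an at least 71-fold higher number from compound 1 to compound 3 (1.85 log units; beyond the scatter), also large and beyond the scatter. Compound 4 carries both exchanges relative to compound 1. On these data alone, both steps end at a limit, so their full size is unknown, and both run towards a higher number.

Neither step points to a recovery in this assay, so no step beyond the scatter is expected, and any movement would be expected towards a higher number. The estimate for compound 4 is 30000 nM, with an expected range of 15000 nM to 80000 nM. This estimate means an expected step that the limit leaves unreadable from compound 3 to compound 4, and a report of a limit alone is the likely outcome.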

Compound 4, half-maximal inhibitory concentration: > 20000 nM
Compound 4 ended at the assay's limit (the forecaster's own chance of this, stated with the estimate: 90%); the middle value lies beyond the limit too.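

In this assay compound 4 gives only a limit, so neither the step from compound 3 to compound 4 nor the step from compound 2 to compound 4 can be read: the limit of > 20000 nM in this assay, at which 3 of the 4 values shown sit.

The compounds shown leave open how far compound 2, compound 3 and compound 4 lie past that limit, and whether they differ from one another at all.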